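Phenyl for Pyrazolyl on the Ether Side Chain

The source may report more compounds than this note shows. Statements on the series, on what has been measured and on what is new or still open speak of the compounds shown alone.

Compound 1 `Cc1nn(-c2ncnc3nc[nH]c23)c2c1C(C(=O)Nc1ccccc1)CC(=O)N2` gives 10 nM in a functional assay on HEK293 cells for agonist activity at G-protein coupled receptor 39 (Homo sapiens), read by scintillation proximity assay and inositol phosphate accumulation, with a stated time of 75 min, in the presence of a further agent that is not named here; on this read-out lower numbers stand for an effect already at smaller amounts and higher numbers for an effect only at larger amounts of compound. Compound 2 `Cc1nn(-c2ncnc3nc[nH]c23)c2c1C(OCCn1cccn1)CC(=O)N2` gives 16 nM. The step of a 1.6-fold higher number from compound 1 to compound 2 (0.20 log units; within the scatter) leaves these two compounds within the scatter of each other, so compound 2 stands level with compound 1. Compound 3 `Cc1nn(-c2ncnc3nc[nH]c23)c2c1C(OCCc1ccccc1)CC(=O)N2` differs from compound 2 by phenyl in place of 1H-pyrazol-1-yl on a saturated chain carbon, two bonds along the chain from an oxygen on a saturated carbon. For the measured compounds named here, no measured step swaps these two rings; the only step, a 1.6-fold higher number from compound 1 to compound 2 (0.20 log units; within the scatter), exchanged a different group and stayed within the scatter. A change of a 1.3-fold higher number from compound 2 to compound 3 (0.10 log units; within the scatter) is therefore expected, nothing beyond the scatter. Compound 3 is estimated at 20 nM, between 7 nM and 60 nM.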

Compound 3, half-maximal effective concentration: 3 nM
Beside the measured number, compound 3's estimate is 6.7-fold (0.82 log units) above it, and the stated range ends above it.
By their numbers in this assay, from the lowest: compound 3; then compounds 1 and 2 (each within the scatter of the next).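

In this assay the ring at the end of the ether side chain matters: phenyl in place of 1H-pyrazol-1-yl gives a 5.3-fold lower number from compound 2 to compound 3 (0.73 log units; beyond the scatter) and so moves the number beyond the scatter, which the earlier exchange on the saturated ring carbon did not do. Phenethyloxy in place of phenylcarbamoyl likewise gives a 3.3-fold lower number from compound 1 to compound 3 (0.52 log units; beyond the scatter) and also lies beyond the scatter. Nothing measured here explains either step.

As far as these compounds go, whether a pyridine ring, a chlorophenyl group or a longer chain ending in phenyl would keep this level remains open.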